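Methoxy in place of hydroxy on the naphthamide ring

A few compounds are considered here, and "the series" means these few. Any claim that something is new, unique, unknown or untested is made for them only; others in the source may bear on it.

Notes on a pair of naphthoquinone amides. Compound 1 `COC1=C(CC(C)(C)CNC(=O)c2ccc3ccccc3c2OC)C(=O)c2ccccc2C1=O` is the reference point: in a functional assay on MCF7 cells (Homo sapiens) for cytotoxicity, read by resazurin assay, with a stated time of 3 days (a higher number here means a weaker inhibitor, a lower number a stronger inhibitor), compound 1 gives 95700 nM, which is weak inhibition. Compound 2 `COc1cc(C(=O)NCC(C)(C)CC2=C(O)C(=O)c3ccccc3C2=O)c(OC)c2ccccc12` carries a free hydroxy on the quinone and an additional methoxy on the naphthamide ring; in this assay compound 2 is recorded as "not active" (no number reported), so no number stands for it and its position on the scale cannot be fixed beyond saying that no measurable inhibition was reported. Compound 3 `COC1=C(CC(C)(C)CNC(=O)c2cc(OC)c3ccccc3c2OC)C(=O)c2ccccc2C1=O` has not yet been tested. Compared with compound 2 the change is methyl in place of hydrogen on an oxygen on an unsaturated carbon; read one bond further out, hydroxy to methoxy. Within the data shown here, no measured pair in this small set isolates this change, so its size in this assay cannot be taken from the data; with compound 1, the only numbered analogue, itself weak, the expectation is a step of no more than the usual scatter, most likely toward a weak value or again no reportable number. Compound 3 is estimated in this assay at 100000 nM, with a range of 30000 nM to 300000 nM.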

Compound 3, half-maximal inhibitory concentration: "not active" (no number reported)
Compound 3: no number reported; the estimate stays without a comparison.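

Compound 2 and compound 3 are both recorded as "not active" in this assay, with no number reported, so no step can be read between them. No evidence shown bears on this result. The compounds shown leave open whether hydroxy to methoxy at this place has any measurable effect in this assay.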